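This account rests on a few compounds, and the source may have more. Where it says the series, first, only, none or still open, it means among the compounds named here.

Measured compounds:
compound 1, `COc1ccc(Nc2cncc(N3CC4CC(C3)N4)c2)cc1`, 2.2 nM;
compound 2, `Clc1ccc(Nc2cncc(N3CC4CC(C3)N4)c2)cc1`, 1.2 nM;
compound 3, `Oc1ccc(Nc2cncc(N3CC4CC(C3)N4)c2)cc1`, 0.988 nM.

All three share one core and differ only in the group on the aniline-type ring. In an assay on HEK293 cells for displacement of a labelled ligand from Neuronal acetylcholine receptor; alpha3/beta4 (Homo sapiens) (on this read-out higher numbers stand for weaker inhibition and lower numbers for stronger inhibition), compound 3 gives the lowest number of the three, but its margin over compound 2 is small: a 1.2-fold lower number from compound 2 to compound 3 (0.08 log units; within the scatter). Only against compound 1 does the gap stand out: a 2.2-fold lower number from compound 1 to compound 3 (0.35 log units; beyond the scatter).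

Compound 4, `Clc1cccc(Nc2cncc(N3CC4CC(C3)N4)c2)c1`, has not been measured yet. It differs from compound 3 by 3-chlorophenyl in place of 4-hydroxyphenyl on a nitrogen on an aromatic ring. The closest measured guide is the step from compound 2 to compound 3, where chloro gave way to hydroxy and the number hardly moved: a 1.2-fold lower number from compound 2 to compound 3 (0.08 log units; within the scatter). For the measured compounds named here, compound 4 also carries chloro, but in a place on the ring that none of the measured compounds tests, as the structure of compound 2 shows. The step from compound 1 to compound 2 swapped methoxy for chloro with a change within the scatter: a 1.8-fold lower number from compound 1 to compound 2 (0.26 log units; within the scatter). Taken together, the three compounds suggest this ring tolerates varied groups with little effect, so no step beyond the scatter is expected for compound 4. The estimated outcome is a 1.8-fold higher number from compound 3 to compound 4 (0.26 log units; within the scatter). Compound 4 is therefore expected to give about 1.8 nM in this assay, with a range from 0.6 nM to 5.5 nM.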

Compound 4, inhibition constant: 293 nM
Compound 4: the middle estimate sits 160-fold (2.21 log units) below what was measured, outside the stated range (above it).
By their numbers in this assay, from the lowest: compounds 3, 2 and 1 (each within the scatter of the next, the first and the last beyond it); then compound 4.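

In this assay compound 2 and compound 4 carry exactly the same atoms, so their comparison tests one thing alone: where the chloro sits on the ring. With 3-chlorophenyl in place of 4-chlorophenyl, binding becomes far weaker (a 240-fold higher number from compound 2 to compound 4 (2.39 log units; beyond the scatter)), showing that the place of a group on this ring can matter far more than the earlier swaps of one group for another suggested. The step from the hydroxy compound is of similar size (a 300-fold higher number from compound 3 to compound 4 (2.47 log units; beyond the scatter)), so compound 3 and compound 2, which lie within the scatter of each other, both stand far from compound 4, and no measured evidence here explains why this shift has so large an effect.

For the compounds shown here, with only one compound carrying a 3-substituted ring, it remains open whether the weak binding belongs to chloro in particular or would also appear with 3-hydroxyphenyl, 3-methylphenyl or 3-aminophenyl. Plain phenyl, with no group on the ring at all, would show whether the 3-chloro arrangement weakens binding or whether the groups of compound 1, compound 2 and compound 3 are what supports it.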